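Methoxy for chloro on the pyridine of compound 1

This account rests on a few compounds, and the source may have more. Where it says the series, first, only, none or still open, it means among the compounds named here.

Three amides sharing the same azetidine-linked dichloropyridine were measured in an ADME assay on a cell-free system (plasma, Homo sapiens) for protein binding; on this read-out higher numbers stand for a larger free fraction and lower numbers for a smaller free fraction. Compound 1 `Cc1c2cc(C(=O)NC3CN(c4cc(Cl)ncc4Cl)C3)ncc2nn1C` gives 0.014, the lowest of the three numbers. Compound 2 `Cc1nc2ccc(C(=O)NC3CN(c4cc(Cl)ncc4Cl)C3)cn2c1C` gives 0.03, and compound 3 `Cc1nn(C)c2cnc(C(=O)NC3CN(c4cc(Cl)ncc4Cl)C3)cc12` gives 0.039; both stand above compound 1 by more than the usual scatter, so compound 1 has the smallest free fraction of the set on this read-out. Within the data shown here, no single-point step between these measured compounds exists, since each pair differs in more than one place.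

Among the measured compounds shown here, the unmeasured compound 4 `COc1cc(N2CC(NC(=O)c3cc4c(C)n(C)nc4cn3)C2)c(Cl)cn1` is the one closest to compound 1: it differs from it in a single place, (methoxy in place of chloro on an aromatic carbon). Cut one bond further out, this reads as 2,5-dichloropyridin-4-yl becoming 5-chloro-2-methoxypyridin-4-yl.

For the measured compounds named here, with no measured step to lean on, the author expects the step in this assay from compound 1 to compound 4 to be small, a 1.4-fold higher number from compound 1 to compound 4 (0.15 log units; within the scatter), with a slight lean toward a larger free fraction but probably not beyond the scatter. The estimated unbound fraction for compound 4 in this assay is therefore 0.02, within the range 0.01 to 0.04.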

Compound 4, unbound fraction: 0.017
Beside the measured number, compound 4's estimate is 1.2-fold (0.07 log units) above it, and the stated range covers the measured number.
By their numbers in this assay, from the lowest: compounds 1, 4, 2 and 3 (each within the scatter of the next, the first and the last beyond it).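

In this assay, among these compounds, the first single-place step of the set reads a 1.2-fold higher number from compound 1 to compound 4 (0.08 log units; within the scatter), which lies within the scatter, so methoxy in place of chloro on this aromatic carbon, next to the ring nitrogen and para to a chloro group, leaves no readable change in the free fraction. The earlier compounds shown here differ from one another in more than one place, so they showed a spread of values across the set but could not isolate what this position contributes. Here one chlorine gives way to a carbon and an oxygen, with one hydrogen-bond acceptor entering, and the number stays within the scatter, though nothing available explains this result.

On these data alone, it remains open whether a different group on this carbon, such as an amine, a hydroxyl or a longer chain like ethoxy, would move the free fraction beyond the scatter, and what replacing the second chloro group would do. As far as these compounds go, it is equally open whether methoxy for chloro would give a similar step on the cores of compound 2 and compound 3.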